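Removing the bromo from compound 1: expected inhibition

A few compounds are considered here, and "the series" means these few. Any claim that something is new, unique, unknown or untested is made for them only; others in the source may bear on it.

Measured so far:
compound 1 `Cc1ccc(S(=O)(=O)n2cc(-c3cc(C(F)(F)F)ccn3)c3cc(Br)ccc32)cc1`: 20.6%
compound 2 `Cc1ccc(S(=O)(=O)n2cc(-c3cc(C(F)(F)F)cc(-c4cn(S(=O)(=O)c5ccc(C)cc5)c5ccccc45)n3)c3ccccc32)cc1`: 27.6%

For the measured compounds named here, only two compounds have a number in a functional assay on A549 cells (Homo sapiens) for inhibition, tested at 10 uM; on this read-out higher numbers stand for a stronger effect at the one concentration tested and lower numbers for a weaker effect. Compound 1 gives 20.6% and compound 2 gives 27.6%; the two numbers lie within the scatter of each other, so compound 1 is not set apart from compound 2 on this read-out. Going by the values given here, no pair of measured compounds differing in one place exists, so no step size is known.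

Compound 3 `Cc1ccc(S(=O)(=O)n2cc(-c3cc(C(F)(F)F)ccn3)c3ccccc32)cc1` is not yet measured. It differs from compound 1 by hydrogen in place of bromo on an aromatic carbon. Among the compounds with values here, with no measured step to lean on, and both known numbers low, no change beyond the scatter is expected in this assay for this step; the loss of the bromo is taken as roughly neutral. Compound 3 is thus expected near compound 1, at 18% with a range from 5% to 35%, which means an estimated step of a number 2.6 percentage points lower from compound 1 to compound 3 (within the scatter).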

Compound 3, a percentage reported as inhibition, at one concentration (the size of the read-out at that concentration, not a potency): 35%
Estimate against measurement, compound 3: 17 percentage points below; measured number inside the range.
By their numbers in this assay, from the lowest: compounds 1, 2 and 3 (each within the scatter of the next, the first and the last beyond it).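

In this assay the series now has its first one-place step: hydrogen in place of bromo on the aromatic carbon gives a number 14.4 percentage points higher from compound 1 to compound 3 (beyond the scatter). For the compounds shown here, the bromo at this position is therefore not required for inhibition at the one concentration tested, and compound 3 without it reads higher than compound 1, which the earlier compounds could not show. Nothing measured here accounts for the direction of this step.

Open, going by these compounds, is how other groups on this same carbon, such as fluoro, methoxy or an amine, would compare with the bromo of compound 1 and the hydrogen of compound 3. Also open is what the trifluoromethyl contributes, since no compound shown differs from compound 3 at that group alone, so a nitrile or a carboxylic acid in its place remains unread.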